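Capping the Phenol: the Methoxy Analogue of Compound 1

The source may hold more compounds than are shown below. What is called first, only, known or untested is meant among the compounds shown, and "the series" means these compounds.

For the measured compounds named here, compound 1 `O=C(Nc1cccc(-n2cc(-c3ccncc3)c(-c3cc(O)cc(Cl)c3)n2)c1)Nc1ccc(Cl)c(C(F)(F)F)c1` is one of two compounds measured in a functional assay on OVCAR-4 cells (Homo sapiens) for inhibition, read by sulforhodamine B assay, with a stated time of 48 h, tested at 100 uM; a lower number here means a stronger effect, a higher number a weaker effect of the compound at the concentration tested. In this assay compound 1 gives -10%, the lower of the two numbers, while compound 2 `O=C(Nc1cccc(-n2cc(-c3ccncc3)c(-c3cc(O)cc(Cl)c3)n2)c1)Nc1ccc(Cl)c(Cl)c1` gives 9%. Going by the values given here, the single step between them, a number 19 percentage points higher from compound 1 to compound 2 (beyond the scatter), is a chloro in place of trifluoromethyl on an aromatic carbon.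

Compound 3 `COc1cc(Cl)cc(-c2nn(-c3cccc(NC(=O)Nc4ccc(Cl)c(C(F)(F)F)c4)c3)cc2-c2ccncc2)c1` differs from compound 1 elsewhere: methyl in place of hydrogen on an oxygen on an aromatic ring. Among the compounds with values here, no measured step concerns this oxygen, so the step from compound 1 to compound 2 does not bear on it, and the expectation for this assay rests on no direct precedent. With both measured numbers close to zero and only a modest step between them, no step beyond the scatter is expected, and the expected step is a number 10 percentage points higher from compound 1 to compound 3 (within the scatter). For compound 3 the estimate in this assay is 0%, with an expected range from -25% to 30%.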

Compound 3, a percentage reported as activity, at one concentration (the size of the read-out at that concentration, not a potency): -16%
The estimate for compound 3 lay 16 percentage points above the measured number; measured number inside the range.
By their numbers in this assay, from the lowest: compounds 3 and 1 (each within the scatter of the next); then compound 2.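

Going from hydroxy to methoxy on the 3-chloro-5-hydroxyphenyl group gives in this assay a number 6 percentage points lower from compound 1 to compound 3 (within the scatter) and so shows that methyl can take the place of hydrogen on this oxygen without a change that stands out from the scatter. For the compounds shown here, the only earlier step, a number 19 percentage points higher from compound 1 to compound 2 (beyond the scatter) for chloro in place of trifluoromethyl, lay elsewhere on the molecule and said nothing about this oxygen. Nothing at hand explains why this pair reads alike.

The compounds shown leave open whether an ethoxy group or a longer chain on this oxygen would also read like compound 1, and whether an amine or a carboxylic acid in place of the hydroxy would do so. They also leave open whether the same change would read alike on compound 2, which carries chloro in place of trifluoromethyl.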